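The source may hold more compounds than are shown below. What is called first, only, known or untested is meant among the compounds shown, and "the series" means these compounds.

Working notes on the series. In a functional assay on HepG2 cells (Homo sapiens) for antiproliferative activity, read by sulforhodamine B assay, with a stated time of 48 h (on this read-out lower numbers stand for stronger inhibition and higher numbers for weaker inhibition), compound 1 (`COc1ccc(/C=C/C(=O)c2ccccc2-c2ccc(OC)c(OC)c2)cc1OC`) gives 3200 nM and compound 2 (`COc1ccc(/C=C/C(=O)c2ccccc2-c2ccc(F)cc2)cc1OC`) gives 95 nM. Among the compounds with values here, compound 2 therefore holds the lower of the two numbers so far. Within the data shown here, the only measured step is a 34-fold lower number from compound 1 to compound 2 (1.53 log units; beyond the scatter), a large one beyond the scatter, with 4-fluorophenyl in place of 3,4-dimethoxyphenyl on an aromatic carbon.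

Next in line is compound 3 (`COc1cc(/C=C/C(=O)c2ccccc2-c2ccc(F)cc2)ccc1O`). Its difference from compound 2 is hydrogen in place of methyl on an oxygen on an aromatic ring, or methoxy to hydroxy. The measured step changes a different place and a much larger group, so its size does not carry over to this change. The series holds no measured methoxy to hydroxy step, and the guidance is thin. A modest step is expected in this assay, towards a higher number, and it may not exceed the scatter. The expected step is a 1.8-fold higher number from compound 2 to compound 3 (0.25 log units; within the scatter). For compound 3 the estimated value is 170 nM, with an expected range of 45 nM to 650 nM.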

Compound 3, half-maximal inhibitory concentration: 2800 nM
The estimate for compound 3 lay 16-fold (1.22 log units) below the measured number; measured number above the stated range.
By their numbers in this assay, from the lowest: compound 2; then compounds 3 and 1 (each within the scatter of the next).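

With a 29-fold higher number from compound 2 to compound 3 (1.47 log units; beyond the scatter) in this assay, this oxygen on the aromatic ring proves to be a sensitive place: the change from methoxy to hydroxy removes only a methyl, a single heavy atom, yet the step is large and beyond the scatter. The series now holds two large steps in two different places, the earlier one being a 34-fold lower number from compound 1 to compound 2 (1.53 log units; beyond the scatter), so the low number of compound 2 is lost when either the 4-fluorophenyl or this methoxy is changed in the way shown. No measurement is available that would explain the size of the step on this oxygen.

On these data alone, it remains open whether the number responds to the methyl itself or to the free hydroxy, which an ethoxy group or a longer alkoxy chain on the same oxygen, or an amine in place of the hydroxy, would help to separate. As far as these compounds go, it is also open whether the other methoxy of compound 2 responds to the same change in the same way, since these compounds test only one of the two.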